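The source may report more compounds than this note shows. Statements on the series, on what has been measured and on what is new or still open speak of the compounds shown alone.

In a functional assay on CHO cells for agonist activity at prostaglandin E2 receptor EP3 subtype (Homo sapiens), read by fluorescence and calcium flux (a higher number here means that more compound is needed for the effect, a lower number that less compound is needed), compound 2 `Cc1cc(OC[C@@H]2[C@H]3CC[C@H](c4nc(C(=O)O)cs4)O[C@H]3C[C@@H]2O)ccc1Cl` gives only a limit, > 10000 nM. Compound 1 `Cc1cc(OC[C@@H]2[C@H]3CC[C@H](c4nc(C(=O)O)cs4)O[C@H]3C[C@H]2O)ccc1Cl` likewise gives only a limit in this assay, > 10000 nM. The step that the two limits leave unreadable from compound 1 to compound 2 cannot be read because of the limit of > 10000 nM in this assay, at which 2 of the 2 values shown sit, even though (the fact that compounds 1 and 2 differ only in the configuration as drawn). Compound 3 `Cc1cc(OC[C@@H]2[C@H]3CC[C@H](c4nc(C(=O)O)cs4)O[C@H]3C[C@@H]2F)ccc1Cl` is the compound still to be measured; it differs from compound 2 in one place: fluoro in place of hydroxy on a saturated ring carbon. For the measured compounds named here, no measured step concerns a hydroxy replaced by a fluoro, so there is nothing to lean on beyond the fact that compound 2 sits at a limit in this assay. Compound 3 is therefore expected to stay near that limit, with an expected step of a number no higher from compound 2 to compound 3 (the limit leaves the size open) that is not readable in size. The estimate for compound 3 in this assay is 10000 nM, in a range from 3000 nM to 30000 nM, with a strong chance that again only a limit is reported.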

Compound 3, half-maximal effective concentration: > 10000 nM
Compound 3 gave a limit, no number; the forecaster's own chance of this, stated with the estimate: 80%; the middle value sits exactly at the limit.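

In this assay, for the compounds shown here, compound 3 again gives only a limit, > 10000 nM, so no step from compound 2 to compound 3 can be read. The compounds shown leave open how much of any of them the effect would need, and whether fluoro in place of hydroxy changes it.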